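The compounds below may be only part of what the source reports. "The series", "measured", "known", "first", "only" and "open" are said of these compounds alone.

Compound 1 `CCCCc1nc(=O)c(S(=O)(=O)c2ccc(-c3cccnc3)cc2)c(O)n1-c1c(OC)cccc1OC` is one of a small group of closely related sulfones built on a shared core. In an ADME assay for permeability, using PAMPA, at pH 5.5 (a lower number here means that the compound crosses the layer more slowly, a higher number that the compound crosses the layer faster), compound 1 gives 202 nm/s. Two relatives sit beside it. Compound 3 `COc1cccc(OC)c1-n1c(CCC(C)C)nc(=O)c(S(=O)(=O)c2ccc(-c3ccc(F)nc3)cc2)c1O` carries a 6-fluoropyridin-3-yl group and a branched chain in place of the straight one; in this assay compound 3 gives 246 nm/s, and the two numbers lie within the scatter of each other, so they show no difference that can be trusted. Compound 2 `CCCCc1[nH]c(=O)c(S(=O)(=O)c2ccc(-c3ccc(F)nc3)cc2)c(O)c1-c1c(OC)cccc1OC` has a changed core, and in this assay compound 2 gives "not determined" (no result reported), so it adds no number to the comparison. Among the compounds with values here, compound 1 therefore holds one of only two usable numbers, and neither stands apart from the other.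

Compound 4 `CCCCc1nc(=O)c(S(=O)(=O)c2ccccc2)c(O)n1-c1c(OC)cccc1OC` differs from compound 1 in a single place: hydrogen in place of pyridin-3-yl on an aromatic carbon. Within the data shown here, no pair of measured compounds shows this exact change, so its effect here is unknown. The expectation for compound 4 is a step from compound 1 of a 1.5-fold higher number from compound 1 to compound 4 (0.17 log units; within the scatter), a modest rise that may not clear the scatter. On that basis the estimate for compound 4 in this assay is 300 nm/s, expected to fall between 150 nm/s and 600 nm/s.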

Compound 4, apparent permeability: 141 nm/s
Compound 4: middle estimate off by 2.1-fold (0.33 log units), on the high side, outside the stated range (below it).
By their numbers in this assay, from the lowest: compounds 4, 1 and 3 (each within the scatter of the next).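

Replacing pyridin-3-yl with hydrogen on the aromatic carbon para to a large group strips away a whole aromatic ring, yet in this assay the result is a 1.4-fold lower number from compound 1 to compound 4 (0.16 log units; within the scatter). Within the data shown here, this is the first direct look at this position, since the earlier compounds differ from each other in more than one place, and it shows that even a change this large gives no difference that can be trusted here. The 4-(pyridin-3-yl)phenyl group can therefore be cut back to phenyl with the read-out staying within the usual scatter, although no measurement is available to explain why.

This single pair tests only the complete loss of the outer ring, so it cannot show what the ring nitrogen contributes, which a plain phenyl group in place of pyridin-3-yl would address. It also leaves open how a charged or hydrogen-bonding group on the same aromatic carbon, such as an amine or a carboxylic acid, would read in this assay.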